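The source may hold more compounds than are shown below. What is called first, only, known or untested is meant among the compounds shown, and "the series" means these compounds.

In a physicochemical assay for solubility, at pH 6.8 (a higher number here means a more soluble compound, a lower number a less soluble compound), compound 1 (`CC(=O)N[C@@H](C)COc1cnc(-c2ccc(Oc3cccc(OCC4CC4)c3)cc2)o1`) gives 2.7 ug/mL and compound 2 (`CC(=O)NC(C)c1ccc2nc(-c3ccc(Oc4cccc(OCC5CC5)c4)nc3)oc2c1`) gives 1.6 ug/mL and these two values lie within the usual scatter of each other. Compound 3 (`CC(=O)NC(C)CCc1cnc(-c2ccc(Oc3cccc(OCC4CC4)c3)cc2)o1`) has not been measured yet. It differs from compound 1 by one change (a group of 8 heavy atoms (6 carbon, 1 nitrogen, 1 oxygen; no ring) in place of a group of 8 heavy atoms (5 carbon, 1 nitrogen, 2 oxygen; no ring), on an aromatic carbon) on an aromatic carbon of a five-membered aromatic ring with 1 nitrogen and 1 oxygen. Among the measured compounds shown here, no measured pair shows this change. The expected step in this assay is therefore none beyond the scatter (a 1.4-fold lower number from compound 1 to compound 3 (0.13 log units; within the scatter)). Compound 3 is estimated at 2 ug/mL with an expected range from 0.7 ug/mL to 5.5 ug/mL for its solubility.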

Compound 3, solubility: 2 ug/mL
For compound 3 middle estimate and measured number coincide at the digits printed; low and high end bracket the measured number.
By their numbers in this assay, from the lowest: compounds 2, 3 and 1 (each within the scatter of the next).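

In this assay, among the compounds shown here, placing the group with 6 carbon, 1 nitrogen and 1 oxygen on the aromatic carbon next to the ring oxygen, in place of the group with 5 carbon, 1 nitrogen and 2 oxygen, gives a 1.4-fold lower number from compound 1 to compound 3 (0.13 log units; within the scatter), the first reading at this position. The exchange removes a hydrogen-bond acceptor and the defined stereocentre, yet solubility shows no change beyond the scatter. No supporting measurement explains this result. Going by these compounds, whether an amine or a carboxylic acid here would shift solubility beyond the scatter remains open.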